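The source may report more compounds than this note shows. Statements on the series, on what has been measured and on what is new or still open speak of the compounds shown alone.

The measured compounds are:

compound 1, `O=C(O)Cc1sc(COc2ccc(Cl)cc2)nc1-c1ccc(Cl)cc1`: 50%
compound 2, `O=C(O)Cc1sc(C(c2ccccc2)c2ccc(Cl)cc2)nc1-c1ccc(Cl)cc1`: 80%
compound 3, `Nc1cc(-c2nc(C(c3ccc(F)cc3)c3ccc(F)cc3)sc2CC(=O)O)cc(F)n1`: 30%

In an in vitro functional assay on HEK285-7 cells for antagonist activity at prostaglandin D2 receptor 2 (Homo sapiens), read by BRET and beta-arrestin recruitment (on this read-out lower numbers stand for smaller maximal responses and higher numbers for larger maximal responses), compound 1 gives 50%, the second highest of the three numbers. Its nearest neighbour is compound 3, which in this assay gives 30%, a number lower than that of compound 1 and beyond the scatter. Furthest from it is compound 2, which in this assay gives 80%, a number higher than that of compound 1, again beyond the scatter. Compounds 2 and 3 differ from compound 1 in more than one place, so none of these pairs isolates a single change.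

Compound 4, `O=C(O)Cc1sc(CSc2ccccc2)nc1-c1ccc(Cl)cc1`, has not yet been measured. It differs from compound 1 in one place: phenylsulfanyl in place of 4-chlorophenoxy on a saturated chain carbon bound to an aromatic carbon. Among the measured compounds shown here, no pair of measured compounds shows this change on its own, so there is no step to lean on.

The account therefore rests on compound 1 alone. Since the change keeps one aromatic ring in the same place and removes only one heavy atom, compound 4 is expected to stay close to compound 1 in this assay. The step of no change at the digits printed from compound 1 to compound 4 (within the scatter) is estimated to be none beyond the scatter. Compound 4 is expected to give 50% in this assay, within a range from 30% to 70%.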

Compound 4, largest response reached (reported as efficacy), in percent of the reference or control that the assay uses: 50%
Beside the measured number, compound 4's estimate shows no gap at the digits printed, within the range that was stated.
By their numbers in this assay, from the lowest: compound 3; then compounds 1 and 4 (each within the scatter of the next); then compound 2.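

Among the compounds shown here, until now, no pair of compounds isolated a change at this place; in this assay, phenylsulfanyl in place of 4-chlorophenoxy on a saturated chain carbon bound to an aromatic carbon gives no change at the digits printed from compound 1 to compound 4 (within the scatter). For the compounds shown here, this is the first single-place comparison in the set, and it shows that the maximal response stays within the scatter when this group is exchanged while the rest of the core of compound 1 is kept. The exchange is a double one, however: the oxygen gives way to sulfur and the chlorine leaves in the same step, so the matching numbers describe the two alterations only taken together, and they do not show that each alone would leave the response unchanged.

A phenoxy group or a 4-chlorophenylsulfanyl group at this place would pull the two alterations apart, and an amine or a longer chain there would test how far the response holds beyond groups that carry a six-membered aromatic ring of carbon only. The compounds shown offer no independent measurement that could explain why the two numbers agree.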